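Replacing Cyclohexyl with Fluorobenzyl in an Adenosine A3 Series

The source may hold more compounds than are shown below. What is called first, only, known or untested is meant among the compounds shown, and "the series" means these compounds.

Compound 1 `CC(C)Nc1nc(N)n2nc(-c3ccco3)nc2n1` gives 568 nM
Compound 2 `c1coc(-c2nc3nc(NC4CCCCC4)nc(NC4CCCCC4)n3n2)c1` gives 129 nM
Compound 3 `c1ccc(CNc2nc(NC3CCCCC3)n3nc(-c4ccco4)nc3n2)cc1` gives 455 nM

All three numbers come from an assay on CHO cells for displacement of a labelled ligand from adenosine receptor A3 (Homo sapiens); on this read-out lower numbers stand for stronger inhibition and higher numbers for weaker inhibition. Among them, compound 2 stands lowest, meaning it is the strongest inhibitor of the three; the nearest to it is compound 3, and compound 1 lies furthest away. Going by the values given here, the only step between two measured compounds that changes a single place is the one in which a benzyl group takes the place of one of the two cyclohexyl groups on an aromatic nitrogen: a 3.5-fold higher number from compound 2 to compound 3 (0.55 log units; beyond the scatter).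

Compound 4 `Fc1ccc(CNc2nc(NC3CCCCC3)nc3nc(-c4ccco4)nn23)cc1` has not yet been measured. Starting from compound 2, the change is 4-fluorobenzyl in place of cyclohexyl on a nitrogen on an aromatic ring. The step from compound 2 to compound 3 bears directly on this, since there too a benzyl-type group displaced cyclohexyl at the same kind of position, and the number rose modestly but beyond the scatter. The fluorine on the ring is the only further difference, and nothing in the measured set shows what it does. A weakening of about the same size is therefore expected in this assay, a 3.3-fold higher number from compound 2 to compound 4 (0.51 log units; beyond the scatter), giving an estimated value for compound 4 of 420 nM (range 150 nM to 1200 nM).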

Compound 4, inhibition constant: 1300 nM
Beside the measured number, compound 4's estimate is 3.1-fold (0.49 log units) below it; measured number above the stated range.
By their numbers in this assay, from the lowest: compound 2; then compounds 3 and 1 (each within the scatter of the next); then compound 4.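

In this assay, the nitrogen that carries cyclohexyl in compound 2 responds differently to two closely related replacements: 4-fluorobenzyl gives a 10-fold higher number from compound 2 to compound 4 (1.00 log units; beyond the scatter), whereas plain benzyl gave a 3.5-fold higher number from compound 2 to compound 3 (0.55 log units; beyond the scatter). This shows that a benzyl ring here does not set the outcome alone, since compound 3 (455 nM) and compound 4 (1300 nM) differ only by the fluorine on that ring, and the fluorinated compound has the higher number, meaning weaker inhibition. Nothing available explains why this single added atom goes with the further weakening.

From the compounds shown here alone, it remains open whether a chlorine or a methoxy group on the benzyl ring would raise the number as the fluorine does, or whether this rise is particular to fluorine. Going by these compounds, it is also open whether a longer chain such as 2-phenylethyl, or a smaller ring such as cyclopentyl, on the same nitrogen would come closer to compound 2 (129 nM) than either benzyl-type group does.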